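Replacing a pyrimidine ring by a pyridine ring

This account rests on a few compounds, and the source may have more. Where it says the series, first, only, none or still open, it means among the compounds named here.

Measured so far:
- compound 1, `C=CCOc1cc(F)cc(C(=O)NNS(=O)(=O)c2ccccc2F)c1`: 0.217 h
- compound 2, `Cc1cc(-n2nccn2)cc(C(=O)NNS(=O)(=O)c2ccccc2)c1F`: 1.02 h
- compound 3, `Cc1cc(-c2ncccn2)cc(C(=O)NNS(=O)(=O)c2ccccc2)c1F`: 2.72 h

In an ADME assay on microsomes from liver (Homo sapiens) for metabolic stability, read by HPLC, using NADPH, with a stated time of 60 min, tested at 1 uM, in the presence of a further agent that is not named here (on this read-out lower numbers stand for a shorter-lived compound and higher numbers for a longer-lived compound), compound 3 gives the highest of the three numbers. Its nearest neighbour is compound 2, which sits a 2.7-fold higher number from compound 2 to compound 3 (0.43 log units; beyond the scatter) below it, a step that comes from a single change: pyrimidin-2-yl in place of 2H-1,2,3-triazol-2-yl on an aromatic carbon. Compound 1, with its quite different core, lies much further down at 0.217 h.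

Compound 4, `Cc1cc(-c2ccccn2)cc(C(=O)NNS(=O)(=O)c2ccccc2)c1F`, has not yet been measured. It differs from compound 3 in one place: pyridin-2-yl in place of pyrimidin-2-yl on an aromatic carbon.

Within the data shown here, no measured step swaps a pyrimidin-2-yl for a pyridin-2-yl, so there is no direct precedent. Among the measured compounds shown here, the only step at the same aromatic carbon, a 2.7-fold higher number from compound 2 to compound 3 (0.43 log units; beyond the scatter), shows that exchanging the ring there can move the half-life beyond the scatter. That step ran toward the pyrimidine; removing one of its nitrogens in compound 4 may undo part of it, but this is uncertain.

Compound 4 is therefore expected to fall somewhat below compound 3, a step of a 1.7-fold lower number from compound 3 to compound 4 (0.23 log units; within the scatter), with the estimate 1.6 h and a range from 0.6 h to 4 h.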

Compound 4, half-life: 1.08 h
The estimate for compound 4 lay 1.5-fold (0.17 log units) above the measured number; low and high end bracket the measured number.
By their numbers in this assay, from the lowest: compound 1; then compounds 2 and 4 (each within the scatter of the next); then compound 3.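

In this assay, the ring on this aromatic carbon now has a third version on the shared core, and removing a single ring nitrogen has a clear result: a 2.5-fold lower number from compound 3 to compound 4 (0.40 log units; beyond the scatter) shows that pyrimidin-2-yl cannot be exchanged for pyridin-2-yl without a loss of half-life beyond the usual scatter. By contrast, a 1.1-fold higher number from compound 2 to compound 4 (0.02 log units; within the scatter) leaves pyridin-2-yl and 2H-1,2,3-triazol-2-yl indistinguishable, so among compounds 2, 3 and 4 only the pyrimidin-2-yl ring of compound 3 stands apart, and changing the aromatic ring at this carbon does not in itself alter the half-life. No measurement is available to explain why this ring stands apart.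

On these data alone, whether pyrimidin-2-yl would give a similar advantage on the core of compound 1, which differs in more than one place, remains open. It is also unknown how a group of a quite different kind at this carbon, such as a morpholine, a simple amine or a carboxylic acid, would compare with these aromatic rings.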